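A few compounds are considered here, and "the series" means these few. Any claim that something is new, unique, unknown or untested is made for them only; others in the source may bear on it.

The measured compounds:
Compound 1 `N#C/C(=C\c1ccc([N+](=O)[O-])cc1)C(=O)c1c[nH]c2ccccc12`: in a functional assay on SJ-G2 cells (Homo sapiens) for inhibition, read by MTT assay, with a stated time of 72 h (on this read-out higher numbers stand for weaker inhibition of growth and lower numbers for stronger inhibition of growth), compound 1 gives 37000 nM.
Compound 2 `N#C/C(=C\c1c(F)c(F)c(F)c(F)c1F)C(=O)c1c[nH]c2ccccc12`: in this assay compound 2 gives 14000 nM.
Compound 3 `COc1ccc(CNC(=O)/C(C#N)=C/c2ccc[nH]2)cc1`: in this assay compound 3 gives only a limit, > 50000 nM.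

Compound 3 thus stands at the limit of this assay (the limit of > 50000 nM in this assay, at which 1 of the 3 values shown sits), whereas compound 1 and compound 2 each give a number within range. Compound 4 `COc1ccc(CNC(=O)/C(C#N)=C/c2ccc(C)cc2)cc1` differs from compound 3 by 4-methylphenyl in place of 1H-pyrrol-2-yl on a double-bonded chain carbon bound to a double-bonded chain carbon. Going by the values given here, no step between measured compounds is known, and compound 1 and compound 2 carry neither the amide nor the 1H-pyrrol-2-yl of compound 3, so they offer no guide to this change. A shift beyond the scatter cannot be grounded in either direction. The step estimated here is a step that the limit leaves unreadable from compound 3 to compound 4. Compound 4 is expected near the limit, at 60000 nM, between 20000 nM and 200000 nM.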

Compound 4, concentration for 50% growth inhibition: 39000 nM
The estimate for compound 4 lay 1.5-fold (0.19 log units) above the measured number; the range from low to high includes it.
By their numbers in this assay, from the lowest: compound 2; then compounds 1 and 4 (each within the scatter of the next). At a limit, above all of these: compound 3.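

In this assay compound 4 gives 39000 nM, a number and not a limit, so this place on the chain can carry 4-methylphenyl, a ring of carbon only without the hydrogen-bond donor of 1H-pyrrol-2-yl. The change gives an at least 1.2-fold lower number from compound 3 to compound 4 (0.10 log units; that floor lies within the scatter). Its true size stays unknown because one end of the step is a limit: the limit of > 50000 nM in this assay, at which 1 of the 4 values shown sits.

The compounds shown leave open how far the number would move with an amine or a carboxylic acid in place of the methyl of 4-methylphenyl.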